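Working notes: hydrogen for methyl in compound 3

A few compounds are considered here, and "the series" means these few. Any claim that something is new, unique, unknown or untested is made for them only; others in the source may bear on it.

compound 1 `O=C1C=CC2(C=C1)OCC(=O)N2c1nc(-c2ccc3ncccc3c2)nn1-c1ccccc1` gives 170 nM
compound 2 `O=C1C=CC2(C=C1)OCC(=O)N2c1nc(-c2ccc3c(c2)OCCO3)nn1-c1ccccc1` gives 170 nM
compound 3 `Cc1ccc(-n2nc(-c3cccc4ccccc34)nc2N2C(=O)COC23C=CC(=O)C=C3)cc1` gives 140 nM

All three values come from a functional assay on A549 cells (Homo sapiens) for antiproliferative activity, with a stated time of 5 days (a higher number here means a weaker inhibitor, a lower number a stronger inhibitor), and cannot be ranked, as compound 3 lies within the scatter of both compound 1 and compound 2. Compound 4 `O=C1C=CC2(C=C1)OCC(=O)N2c1nc(-c2cccc3ccccc23)nn1-c1ccccc1` is related to compound 3 by hydrogen in place of methyl on an aromatic carbon, para to a large group. Within the data shown here, no measured step covers this change. The nearest evidence is no change at the digits printed from compound 1 to compound 2 (within the scatter), a change at a different aryl group that stays within the scatter. The expected step is a 1.1-fold higher number from compound 3 to compound 4 (0.03 log units; within the scatter), with nothing beyond the scatter anticipated. Compound 4 is estimated at 150 nM, with an expected range of 70 nM to 320 nM.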

Compound 4, half-maximal inhibitory concentration: 80 nM
The estimate for compound 4 lay 1.9-fold (0.27 log units) above the measured number; low and high end bracket the measured number.
By their numbers in this assay, from the lowest: compounds 4, 3, 1 and 2 (each within the scatter of the next, the first and the last beyond it).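

In this assay the change from 4-methylphenyl to phenyl gives a 1.8-fold lower number from compound 3 to compound 4 (0.24 log units; within the scatter) so the methyl, para to a large group, shows no resolved effect. Naphthalen-1-yl gives the first steps beyond the scatter, both modest, with a 2.1-fold lower number from compound 2 to compound 4 (0.33 log units; beyond the scatter) against 2,3-dihydro-1,4-benzodioxin-6-yl and a 2.1-fold lower number from compound 1 to compound 4 (0.33 log units; beyond the scatter) against quinolin-6-yl. No available evidence bears on the origin of these steps.

Open, from the compounds shown here alone, is whether naphthalen-2-yl would match naphthalen-1-yl. Also open, going by these compounds, is how an amine or a carboxylic acid on the phenyl would read.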